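A methyl step carried from one core to another

This account rests on a few compounds, and the source may have more. Where it says the series, first, only, none or still open, it means among the compounds named here.

In an assay on cells for inhibition of MAP kinase-interacting serine/threonine-protein kinase 1 (Homo sapiens), read by mobility shift assay, with stated times of 10 min and 60 min, in the presence of a further agent that is not named here (a lower number here means a stronger inhibitor, a higher number a weaker inhibitor), compound 1 `Cc1c(-c2cncc(-c3ccc(C(N)=O)c(OC(C)C)c3)c2)cnn1C` gives 60 nM, and compound 2 `CC(C)Oc1cc(-c2cncc(-c3cnn(C)c3)c2)ccc1C(N)=O` gives 400 nM. The two differ in one place, (methyl in place of hydrogen on an aromatic carbon), and the step of a 6.7-fold lower number from compound 2 to compound 1 (0.82 log units; beyond the scatter) shows that the added methyl is worth something in this series.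

Compound 3 `NC(=O)c1ccc(-c2cccnc2)cc1` is a smaller member of the set; in this assay compound 3 gives 8800 nM, the highest number among the three measured. The difference between the core of compound 3 and the core of compound 2 is not broken down here.

Compound 4 `Cc1ncccc1-c1ccc(C(N)=O)cc1` has not yet been measured. It differs from compound 3 by methyl in place of hydrogen on an aromatic carbon. Going by the values given here, this is the same kind of change as the one from compound 2 to compound 1, but not the same: there the methyl entered a five-membered aromatic ring with 2 nitrogen, next to the ring atom that bears a large group and two ring bonds from the ring nitrogen, whereas here it enters a six-membered aromatic ring with 1 nitrogen, next to the ring nitrogen and ortho to a group of 9 heavy atoms. Among the compounds with values here, the surroundings therefore do not match, and only one earlier step is available to lean on.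

For compound 4 in this assay a step of a 2.5-fold lower number from compound 3 to compound 4 (0.40 log units; beyond the scatter) is expected, smaller than the earlier one, because the step of a 6.7-fold lower number from compound 2 to compound 1 (0.82 log units; beyond the scatter) was measured in a different ring and cannot be assumed to carry over in full. The estimate for compound 4 is 3500 nM, with the likely range from 1000 nM to 12000 nM.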

Compound 4, half-maximal inhibitory concentration: 170000 nM
For compound 4 the middle estimate is 49-fold (1.69 log units) below the measured one, and the stated range ends below it.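

In this assay, methyl in place of hydrogen on an aromatic carbon does not carry from one core to the other, and the two steps run in opposite directions: the same change on two cores in this assay, a 6.7-fold lower number (0.82 log units; beyond the scatter) from compound 2 to compound 1 and a 19-fold higher number (1.29 log units; beyond the scatter) from compound 3 to compound 4, 130-fold (2.11 log units) apart, beyond the scatter of two such steps

The new step, a 19-fold higher number from compound 3 to compound 4 (1.29 log units; beyond the scatter), counts as large and turns the small core of compound 3 into a much weaker inhibitor, so a gain seen for this change on the core of compound 2 gives no safe forecast of even its direction elsewhere in the series. What the pair does not show is which difference sets the outcome, since the two steps differ at once in the ring that takes the methyl, in the place on that ring, and in the rest of the core, and a single step on each core cannot separate these.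

Open, as far as these compounds go, is whether an ethyl group or an amine, set next to the ring nitrogen on the six-membered aromatic ring of compound 3, would follow the methyl or depart from it. Also open, from the compounds shown here alone, is whether the methyl step on that ring would keep its direction on a larger core, such as that of compound 2, where the surroundings differ.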